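The compounds below may be only part of what the source reports. "The series", "measured", "known", "first", "only" and "open" are said of these compounds alone.

Working notes on a short sulfated oligosaccharide series carrying a dithiolane-terminated linker, read in an assay on isolated protein for binding affinity to fibroblast growth factor 2 (Homo sapiens), read by surface plasmon resonance; a lower number here means tighter binding, a higher number weaker binding.

Compound 1 `CC(=O)N[C@H]1[C@@H](OC[C@@H](O)[C@@H](O)[C@H](O)[C@@H](O)CNc2cccc(NC(=O)CCCCC3CCSS3)c2)O[C@H](CO)[C@H](OS(=O)(=O)O)[C@@H]1O[C@@H]1O[C@H](C(=O)O)[C@@H](O)[C@H](OS(=O)(=O)O)[C@H]1O` is the anchor of the set; in this assay compound 1 gives 41 nM. Compound 3 `CC(=O)N[C@H]1[C@@H](OC[C@@H](O)[C@@H](O)[C@H](O)[C@@H](O)CNc2cccc(NC(=O)CCCCC3CCSS3)c2)O[C@H](COS(=O)(=O)O)[C@H](OS(=O)(=O)O)[C@@H]1O[C@@H]1O[C@H](C(=O)O)[C@@H](O)[C@H](OS(=O)(=O)O)[C@H]1O` differs from compound 1 by sulfo in place of hydrogen on an oxygen on a saturated carbon, and in this assay compound 3 gives 60 nM. The resulting step, a 1.5-fold higher number from compound 1 to compound 3 (0.17 log units; within the scatter), is small enough to count as no change on the present evidence.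

Compound 2 `CC(=O)N[C@H]1[C@@H](OC[C@@H](O)[C@@H](O)[C@H](O)[C@@H](O)CNc2cccc(NC(=O)CCCCC3CCSS3)c2)O[C@H](CO)[C@H](O)[C@@H]1O[C@@H]1O[C@H](C(=O)O)[C@@H](O)[C@H](OS(=O)(=O)O)[C@H]1OS(=O)(=O)O` rearranges the same atoms into a different pattern of sulfation on the shared core; the difference between the core of compound 1 and the core of compound 2 is not broken down here. In this assay compound 2 gives 95 nM, a higher number than compound 1 by a margin beyond the scatter, whereas against compound 3 the two values sit within the scatter of each other.

Compound 4 `CC(=O)N[C@H]1[C@@H](OC[C@@H](O)[C@@H](O)[C@H](O)[C@@H](O)CNc2cccc(NC(=O)CCCCC3CCSS3)c2)O[C@H](COS(=O)(=O)O)[C@H](O)[C@@H]1O[C@@H]1O[C@H](C(=O)O)[C@@H](O)[C@H](OS(=O)(=O)O)[C@H]1OS(=O)(=O)O` has not yet been measured. Among the measured compounds shown here, it differs from compound 2 by sulfo in place of hydrogen on an oxygen on a saturated carbon, the same change, at the same kind of place, as the one already seen from compound 1 to compound 3. For the measured compounds named here, with only that one precedent, the expectation for compound 4 rests on the near-null outcome of a 1.5-fold higher number from compound 1 to compound 3 (0.17 log units; within the scatter), so the estimated step is a 1.5-fold higher number from compound 2 to compound 4 (0.17 log units; within the scatter). On that basis compound 4 is expected to give about 140 nM in this assay, with a plausible range from 70 nM to 280 nM.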

Compound 4, dissociation constant: 99 nM
For compound 4 the middle estimate is 1.4-fold (0.15 log units) above the measured one; measured number inside the range.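

In this assay, placing sulfo on an oxygen on a saturated carbon of the core of compound 2 gives a 1.0-fold higher number from compound 2 to compound 4 (0.02 log units; within the scatter), so this second instance of the change, hydroxymethyl to (sulfooxy)methyl, also stays inside the scatter. Across the two cores available, the change therefore carries over as a null result, with no sign that the core alters its outcome: the same change on two cores in this assay, a 1.5-fold higher number (0.17 log units; within the scatter) from compound 1 to compound 3 and a 1.0-fold higher number (0.02 log units; within the scatter) from compound 2 to compound 4, 1.4-fold (0.15 log units) apart, within the scatter of two such steps. Among the compounds shown here, this shows agreement between only two pairs in one assay; it does not show that the change would be silent on a further core, and since neither step departs from the scatter, the series has not yet tested whether a step of real size would carry from one core to another.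

The compounds shown leave open whether another group on that same saturated carbon, such as a phosphate or an amine in place of the sulfooxy, would move the number in this assay on either core. For the compounds shown here, they also leave open whether a longer chain in the dithiolane-terminated linker would alter the outcome of the change, and no single-place step connects the two cores, so their pattern of sulfation cannot be resolved into separate contributions.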